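This account rests on a few compounds, and the source may have more. Where it says the series, first, only, none or still open, it means among the compounds named here.

Compound 1 `COc1ccc(/C=C/C(=O)c2ccc(OC)c3c2OC(C)(C)C=C3)cc1O`: 450 nM
Compound 2 `CCC(=O)Oc1cc(/C=C/C(=O)c2ccc(OC)c3c2OC(C)(C)C=C3)ccc1OC`: 90 nM
Compound 3 `CCCCC(=O)Oc1cc(/C=C/C(=O)c2ccc(OC)c3c2OC(C)(C)C=C3)ccc1OC`: 100 nM

All three were measured in a functional assay on HepG2 cells (Homo sapiens) for cytotoxicity, read by MTT assay; on this read-out lower numbers stand for stronger inhibition and higher numbers for weaker inhibition. Compound 3 sits level with compound 2, a 1.1-fold higher number from compound 2 to compound 3 (0.05 log units; within the scatter), and well under compound 1, a 4.5-fold lower number from compound 1 to compound 3 (0.65 log units; beyond the scatter). Compound 4 `C=CC(=O)Oc1cc(/C=C/C(=O)c2ccc(OC)c3c2OC(C)(C)C=C3)ccc1OC` differs from compound 3 at one place: vinyl in place of butyl on a carbonyl carbon. The closest guide is a 1.1-fold higher number from compound 2 to compound 3 (0.05 log units; within the scatter), a change on the same chain that stayed within the scatter. The larger steps, a 5.0-fold lower number from compound 1 to compound 2 (0.70 log units; beyond the scatter) and a 4.5-fold lower number from compound 1 to compound 3 (0.65 log units; beyond the scatter), came from replacing hydrogen on the oxygen, and compound 4 keeps a carbonyl group there. Among the compounds with values here, no measured compound carries vinyl, so this remains uncertain. The expected change is a 1.1-fold lower number from compound 3 to compound 4 (0.05 log units; within the scatter), with no shift beyond the scatter anticipated. Compound 4 is estimated at 90 nM, within an expected range of 40 nM to 200 nM.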

Compound 4, half-maximal inhibitory concentration: 160 nM
The estimate for compound 4 lay 1.8-fold (0.25 log units) below the measured number; measured number inside the range.
By their numbers in this assay, from the lowest: compounds 2, 3 and 4 (each within the scatter of the next); then compound 1.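

In this assay vinyl on the carbonyl carbon gives a 1.6-fold higher number from compound 3 to compound 4 (0.20 log units; within the scatter) and a 1.8-fold higher number from compound 2 to compound 4 (0.25 log units; within the scatter) so this unsaturated group reads the same here as the two saturated chains. Acylating the oxygen still holds with vinylcarbonyl, which gives a 2.8-fold lower number from compound 1 to compound 4 (0.45 log units; beyond the scatter) and so remains a modest gain beyond the scatter. Nothing available explains these numbers. Still open, as far as these compounds go, is how a phenyl group or a much longer chain on this carbonyl carbon would read, and whether an amine or a carboxylic acid at the end of the chain would move the number.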